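The compounds below may be only part of what the source reports. "The series", "measured", "known", "first", "only" and "open" are said of these compounds alone.

Values in a functional assay on HL-60 cells (Homo sapiens) for cytotoxicity, read by CellTiter-Blue, with a stated time of 48 h; a lower number here means a stronger inhibitor, a higher number a weaker inhibitor:
- compound 1 `COc1cc(OC)cc(-c2ccc3c(c2)C(CC(=O)OCC2CC2)C(C(=O)OCC2CC2)=C(N)O3)c1`: 6700 nM
- compound 2 `CCOC(=O)CC1C(C#N)=C(N)Oc2ccc(-c3cc(OC)cc(OC)c3)cc21`: 19600 nM
- compound 3 `CCOC(=O)CC1C(C(=O)OCC)=C(N)Oc2ccc(-c3cccc(F)c3)cc21`: 76400 nM

Compound 3 stands highest of the three at 76400 nM, which makes it the weakest, with its gaps to compound 2 and compound 1 both beyond the scatter. Compound 4 `CCOC(=O)CC1C(C(=O)OCC)=C(N)Oc2ccc(-c3ccncc3)cc21` has pyridin-4-yl in place of 3-fluorophenyl on an aromatic carbon. Going by the values given here, compound 1 and compound 2 differ from compound 3 in more than one place, so no measured pair isolates this change. In this assay, no step beyond the scatter is therefore expected, and the starting point is compound 3 at 76400 nM. The expected step is a 1.2-fold lower number from compound 3 to compound 4 (0.07 log units; within the scatter). Compound 4 is estimated at 65000 nM, with an expected range of 25000 nM to 170000 nM.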

Compound 4, half-maximal inhibitory concentration: 10200 nM
Compound 4: middle estimate off by 6.4-fold (0.80 log units), on the high side, and the stated range ends above it.
By their numbers in this assay, from the lowest: compounds 1, 4 and 2 (each within the scatter of the next, the first and the last beyond it); then compound 3.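

In this assay, pyridin-4-yl in place of 3-fluorophenyl on this aromatic carbon gives a 7.5-fold lower number from compound 3 to compound 4 (0.87 log units; beyond the scatter), the first single-place change available in the series. It shows that the group at this position can, on its own, move the number beyond the scatter. No supporting evidence accounts for the step. The compounds shown leave open whether pyridin-3-yl or pyridin-2-yl would give a similar step, and whether an unsubstituted phenyl or a phenyl carrying an amine would stand closer to compound 3 or to compound 4.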